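A few compounds are considered here, and "the series" means these few. Any claim that something is new, unique, unknown or untested is made for them only; others in the source may bear on it.

Measured compounds:
Compound 1, `CCCCCCn1cnc2c(Nc3ccc(O)cc3)nc(N[C@H]3CC[C@H](N)CC3)nc21`: 24700 nM
Compound 2, `CC(C)CCn1cnc2c(NCc3cccc(Cl)c3)nc(N[C@H]3CC[C@H](N)CC3)nc21`: 16700 nM
Compound 3, `CC(C)CCn1cnc2c(Nc3ccccc3)nc(N[C@H]3CC[C@H](N)CC3)nc21`: 21700 nM

All three numbers come from a functional assay on HCC827 cells (Homo sapiens) for inhibition, read by fluorescence, with a stated time of 72 h; a lower number here means a stronger inhibitor of growth, a higher number a weaker inhibitor of growth. Compound 1 carries the highest of the three numbers, but its gap to compound 3 and its gap to compound 2 both lie within the scatter, so the three compounds cannot be separated from one another on these data. Within the data shown here, the only step between two compounds that differ in a single place is a 1.3-fold higher number from compound 2 to compound 3 (0.11 log units; within the scatter), and it too stays within the scatter.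

Compound 4, `CCCCCCn1cnc2c(Nc3cccc(Cl)c3)nc(N[C@H]3CC[C@H](N)CC3)nc21`, has not yet been measured in this assay. It is compound 1 with 3-chlorophenyl in place of 4-hydroxyphenyl on a nitrogen on an aromatic ring. Among the measured compounds shown here, no measured pair shows exactly this exchange. The step from compound 2 to compound 3 is the nearest guide, since it also replaces the group on the nitrogen on an aromatic ring, and it moved the number by an amount within the scatter. Compound 1 and compound 3 likewise sit within the scatter of each other. On this basis compound 4 is expected to stay close to compound 1, with a 1.2-fold lower number from compound 1 to compound 4 (0.09 log units; within the scatter) expected to remain within the scatter. The estimate for compound 4 is 20000 nM, with a range from 8000 nM to 50000 nM.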

Compound 4, concentration for 50% growth inhibition: 10200 nM
Compound 4: middle estimate off by 2.0-fold (0.29 log units), on the high side; the range from low to high includes it.
By their numbers in this assay, from the lowest: compounds 4, 2, 3 and 1 (each within the scatter of the next, the first and the last beyond it).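

With the hexyl chain and the rest of the core of compound 1 held fixed, replacing 4-hydroxyphenyl with 3-chlorophenyl on the nitrogen on an aromatic ring gave a 2.4-fold lower number from compound 1 to compound 4 (0.38 log units; beyond the scatter) in this assay and is the only single-place step shown that lies beyond the scatter. The earlier step, a 1.3-fold higher number from compound 2 to compound 3 (0.11 log units; within the scatter), stayed within the scatter and so gave no sign that a change on this nitrogen could separate two compounds, whereas this modest step shows that it can. The exchange removes the hydroxyl group and adds a chlorine in one move, and no data shown explain the step.

As far as these compounds go, what remains open is whether the step follows from losing the hydroxyl group, gaining the chlorine or the different placement of the substituent on the phenyl ring, a question that a plain phenyl, 4-chlorophenyl or 3-hydroxyphenyl group on the same nitrogen, with the hexyl chain kept, could help separate. From the compounds shown here alone, it is also open whether the same exchange would give a step of similar size with a chain other than hexyl on the core.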